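A few compounds are considered here, and "the series" means these few. Any claim that something is new, unique, unknown or untested is made for them only; others in the source may bear on it.

Measured so far:
compound 1, `COc1cc(-c2cc(/C=C/C(=O)c3ccc(Cl)c(Cl)c3)[nH]n2)cc(OC)c1OC`: 34000 nM
compound 2, `COc1ccc(-c2cc(/C=C/C(=O)c3cc(OC)c(OC)c(OC)c3)[nH]n2)cc1OC`: 11700 nM
compound 3, `COc1ccc(-c2cc(/C=C/C(=O)c3ccc(N)cc3)[nH]n2)cc1`: 15400 nM

In a functional assay on OVCAR-8 cells (Homo sapiens) for inhibition, read by sulforhodamine B assay, with a stated time of 48 h (a lower number here means a stronger inhibitor of growth, a higher number a weaker inhibitor of growth), compound 1 gives 34000 nM, the highest of the three numbers; the gap to compound 3 is beyond the scatter, and the gap to compound 2 is wider still. Compound 2 and compound 3 carry methoxy or amino substitution on the aryl ketone side, while compound 1 alone carries chlorine there.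

Compound 4, `COc1ccc(C(=O)/C=C/c2cc(-c3cc(OC)c(OC)c(OC)c3)n[nH]2)cc1OC`, is compound 1 with one change: 3,4-dimethoxyphenyl in place of 3,4-dichlorophenyl on a carbonyl carbon. The new aryl ketone matches the substitution type seen in compound 2, which gives 11700 nM in this assay, though compound 2 and compound 4 differ elsewhere and no direct comparison between them is available.

Within the data shown here, with only three measured compounds and no single-point steps among them, the expectation for compound 4 rests on the trend that the oxygenated aryl ketones sit lower than compound 1. A downward step of modest size, a 2.3-fold lower number from compound 1 to compound 4 (0.36 log units; beyond the scatter), is expected, most likely just beyond the scatter. Compound 4 is estimated at 15000 nM in this assay, with a plausible range from 6000 nM to 40000 nM.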

Compound 4, concentration for total growth inhibition: 2730 nM
Compound 4: middle estimate off by 5.5-fold (0.74 log units), on the high side, outside the stated range (below it).
By their numbers in this assay, from the lowest: compound 4; then compounds 2 and 3 (each within the scatter of the next); then compound 1.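

In this assay the aryl group on a carbonyl carbon proves to be a strong lever on its own: with the rest of the structure held constant, 3,4-dimethoxyphenyl in place of 3,4-dichlorophenyl gives a 12-fold lower number from compound 1 to compound 4 (1.10 log units; beyond the scatter) in this series. The earlier compounds shown here had no pair differing in one place, so they could not tie any shift to this position. No supporting measurement is available to explain the step.

From the compounds shown here alone, whether the step follows from the two methoxy groups entering or the two chlorines leaving remains open, and an unsubstituted phenyl, a phenyl with one methoxy group or a pyridine at this place would help separate the two readings. Whether the same exchange holds on other substitution patterns of the shared core is also unresolved.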